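Ring size at the hydrazone carbon: cyclopropyl to cyclohexyl

A few compounds are considered here, and "the series" means these few. Any claim that something is new, unique, unknown or untested is made for them only; others in the source may bear on it.

Three hydrazone analogues sharing one core were assayed in an assay on isolated protein for inhibition of Amine oxidase [flavin-containing] A (Homo sapiens), read by fluorescence, with a stated time of 20 min; a higher number here means a weaker inhibitor, a lower number a stronger inhibitor. Compound 1 `C=CCC/C(C)=N\Nc1nc(-c2cccc([N+](=O)[O-])c2)cs1` gives 3990 nM. Compound 2 `CCCC/C(C)=N\Nc1nc(-c2cccc([N+](=O)[O-])c2)cs1` gives 6330 nM. Compound 3 `C/C(=N/Nc1nc(-c2cccc([N+](=O)[O-])c2)cs1)C1CC1` gives 2660 nM, the lowest of the three numbers; its nearest neighbour is compound 1, with a 1.5-fold lower number from compound 1 to compound 3 (0.18 log units; within the scatter), and its furthest is compound 2, with a 2.4-fold lower number from compound 2 to compound 3 (0.38 log units; beyond the scatter). The chain variation between the first two, a 1.6-fold higher number from compound 1 to compound 2 (0.20 log units; within the scatter), stayed within the scatter.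

Compound 4 `C/C(=N/Nc1nc(-c2cccc([N+](=O)[O-])c2)cs1)C1CCCCC1` differs from compound 3 only at the hydrazone carbon: cyclohexyl in place of cyclopropyl on a carbon with a double bond to nitrogen. Within the data shown here, two measured steps bear on this change, since both replace an open chain at the same carbon with cyclopropyl: the step from compound 2 to compound 3 was modest and beyond the scatter, while that from compound 1 to compound 3 stayed within it. Cyclohexyl brings a ring, as cyclopropyl does, but a larger one, closer in bulk to the butyl of compound 2. A return toward the region of compound 2 therefore seems the more likely outcome, though a step within the scatter cannot be excluded. For compound 4 in this assay the expected step is a 1.7-fold higher number from compound 3 to compound 4 (0.23 log units; within the scatter). The estimate for compound 4 is 4500 nM, with a range from 1500 nM to 13000 nM.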

Compound 4, half-maximal inhibitory concentration: 29100 nM
Compound 4: the middle estimate sits 6.5-fold (0.81 log units) below what was measured; the measured number lies above the stated range.
By their numbers in this assay, from the lowest: compounds 3, 1 and 2 (each within the scatter of the next, the first and the last beyond it); then compound 4.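

In this assay, among these compounds, ring size at the carbon with a double bond to nitrogen proved to matter: cyclohexyl in place of cyclopropyl gave an 11-fold higher number from compound 3 to compound 4 (1.04 log units; beyond the scatter) as the only large step, so a ring at this carbon does not by itself keep the number low. Cyclohexyl also parted from both open chains, with a 4.6-fold higher number from compound 2 to compound 4 (0.66 log units; beyond the scatter) and a 7.3-fold higher number from compound 1 to compound 4 (0.86 log units; beyond the scatter) as its steps, which shows that compound 4 does not fall in with the butyl of compound 2, the chain that had given the highest number so far. No measurement at hand accounts for this rise.

With only a three-membered and a six-membered ring at this carbon, the compounds shown leave open whether the number climbs steadily with ring size or jumps at some point, which cyclobutyl and cyclopentyl would help to settle. They also leave open whether the rise belongs to the saturated carbon ring itself, a question that phenyl or piperidin-4-yl at the same carbon could address.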